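The compounds below may be only part of what the source reports. "The series", "measured", "known", "first", "only" and "open" are said of these compounds alone.

The measured compounds so far:

Compound 1, `CCOC(=O)C1=C(Nc2ccccc2)S/C(=C\c2ccc(O)c(O)c2)C1=O`, which in a functional assay on MCF7 cells (Homo sapiens) for inhibition, read by MTT assay, with a stated time of 72 h, tested at 10 uM (a lower number here means less inhibition, a higher number more inhibition at the concentration tested (going by the name of the read-out)), gives 38.1%.
Compound 2, `CCOC(=O)C1=C(Nc2ccccc2)S/C(=C\c2ccccc2C(F)(F)F)C1=O`, for which this assay reports only a limit, < 10%.
Compound 3, `CCOC(=O)C1=C(Nc2ccccc2)S/C(=C\c2cc(OC)c(O)c(OC)c2)C1=O`, which in this assay gives 12.9%.

Compound 1 holds the highest of the two numbers; compound 3 sits a gap below it that is beyond the usual scatter, and compound 2 sits at the limit of this assay (the limit of < 10% in this assay, at which 1 of the 3 values shown sits). Compound 4, `CCOC(=O)C1=C(Nc2ccccc2)S/C(=C\c2cccnc2)C1=O`, is not yet measured. It differs from compound 1 in one place: pyridin-3-yl in place of 3,4-dihydroxyphenyl on a double-bonded chain carbon bound to a double-bonded ring carbon. No measured step of this kind is shown, so the expectation rests on the spread of the three values, where only compound 1 reaches a sizeable number. Compound 4 is expected to give 17% in this assay, between 5% and 32%. The expected step of a number 21.1 percentage points lower from compound 1 to compound 4 (beyond the scatter) would be a drop beyond the scatter.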

Compound 4, a percentage reported as inhibition, at one concentration (the size of the read-out at that concentration, not a potency): < 10%
Compound 4 ended at the assay's limit; the forecaster's own chance of this, stated with the estimate: 30%; middle value at least 7 percentage points from the limit.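

In this assay, among the compounds shown here, pyridin-3-yl in place of 3,4-dihydroxyphenyl gives the first single-change step at this position, and it is a clear loss: a number at least 28.1 percentage points lower from compound 1 to compound 4 (beyond the scatter). The value of compound 4, < 10%, is a limit of the assay, not a number. The true size of the drop therefore cannot be read, and this position can clearly change the read-out: the limit of < 10% in this assay, at which 2 of the 4 values shown sit.

The compounds shown leave open whether the hydroxyl groups or the carbon-only ring matter more. A 4-hydroxyphenyl or 3-aminophenyl group at this position could help to separate the two.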